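The source may hold more compounds than are shown below. What is called first, only, known or untested is meant among the compounds shown, and "the series" means these compounds.

Compound 2 `CC(=O)Nc1cccc(C2CCN(CCCn3c(-c4ccc(Cl)cc4F)nc4ccccc43)CC2)c1` gives the lower of the two numbers measured in an assay for displacement of a labelled ligand from melanin-concentrating hormone receptor 1 (Homo sapiens), read by fluorescence (a lower number here means a stronger inhibitor, a higher number a weaker inhibitor), namely 1 nM, while compound 1 `CCc1ccc(-c2nc3ccccc3n2CCCN2CCC(c3cccc(NC(C)=O)c3)CC2)cc1` gives 32 nM. Within the data shown here, the only measured step, a 32-fold lower number from compound 1 to compound 2 (1.51 log units; beyond the scatter), was large. Compound 3 `CC(=O)Nc1cccc(C2CCN(CCCn3c(-c4ccc(F)c(F)c4)nc4ccccc43)CC2)c1` differs from compound 2 by 3,4-difluorophenyl in place of 4-chloro-2-fluorophenyl on an aromatic carbon. Among the measured compounds shown here, both groups in this change carry halogens, so the measured step offers only indirect guidance, and the direction of any shift cannot be read from the numbers so far. A modest step, a 4.0-fold higher number from compound 2 to compound 3 (0.60 log units; beyond the scatter), is expected. Compound 3 is therefore estimated at 4 nM, within a range of 1 nM to 15 nM.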

Compound 3, half-maximal inhibitory concentration: 4 nM
Beside the measured number, compound 3's estimate shows no gap at the digits printed; the measured number falls inside the stated range.
By their numbers in this assay, from the lowest: compound 2; then compound 3; then compound 1.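

Which halogens the phenyl group carries matters at this position: 3,4-difluorophenyl and 4-chloro-2-fluorophenyl both bear halogens, yet they are separated in this assay (a 4.0-fold higher number from compound 2 to compound 3 (0.60 log units; beyond the scatter)). Even so, 3,4-difluorophenyl keeps a good part of the gain over 4-ethylphenyl (an 8.0-fold lower number from compound 1 to compound 3 (0.90 log units; beyond the scatter)). Nothing given here explains either shift.

As far as these compounds go, the swap removes the chlorine and moves a fluorine at once, so the share of each change in the shift stays open. Also open, from the compounds shown here alone, is how a plain phenyl or a methoxyphenyl would compare at this carbon.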